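Methylating a Phenolic Oxygen: Expected Effect on Cell Growth

A few compounds are considered here, and "the series" means these few. Any claim that something is new, unique, unknown or untested is made for them only; others in the source may bear on it.

Of the compounds shown here, three built on one shared core have been tested in a functional assay on HT-29 cells (Homo sapiens) for antiproliferative activity, read by MTT assay, with a stated time of 48 h; on this read-out lower numbers stand for stronger inhibition and higher numbers for weaker inhibition. Compound 1 `O=C(/C=C\Nc1ccc(O)cc1)c1cn(-c2ccccc2)nc1-c1ccccc1` carries a free hydroxy group, and in this assay compound 1 gives 5000 nM. Compound 2 `COc1ccc(N/C=C\C(=O)c2cn(-c3ccccc3)nc2-c2ccccc2)cc1` differs from compound 1 by methyl in place of hydrogen on an oxygen on an aromatic ring, and in this assay compound 2 gives 1560 nM, which amounts to a 3.2-fold lower number from compound 1 to compound 2 (0.51 log units; beyond the scatter). Compound 3 `COc1ccc(-c2nn(-c3ccccc3)cc2C(=O)/C=C\Nc2ccc(O)cc2)cc1` keeps the hydroxy group but has a different core, and in this assay compound 3 gives 2460 nM, which amounts to a 2.0-fold lower number from compound 1 to compound 3 (0.31 log units; beyond the scatter). The numbers for compound 2 and compound 3 lie within the scatter of each other, so no order between them can be read.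

Compound 4 `COc1ccc(N/C=C\C(=O)c2cn(-c3ccccc3)nc2-c2ccc(OC)cc2)cc1` has not yet been measured. It differs from compound 3 by methyl in place of hydrogen on an oxygen on an aromatic ring, the same change made from compound 1 to compound 2. The core of compound 3 and compound 4 differs from that of compound 1 and compound 2 by methoxy in place of hydrogen on an aromatic carbon. The expectation for compound 4 rests on the earlier step, because compound 2 already showed a 3.2-fold lower number from compound 1 to compound 2 (0.51 log units; beyond the scatter) on the other core. The step expected from compound 3 to compound 4 is estimated at a 3.1-fold lower number from compound 3 to compound 4 (0.49 log units; beyond the scatter). Compound 4 is therefore expected to give about 800 nM. The lower end of the estimate for compound 4 is 350 nM. The upper end of the estimate for compound 4 is 1800 nM.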

Compound 4, half-maximal inhibitory concentration: 8760 nM
Compound 4: middle estimate off by 11-fold (1.04 log units), on the low side; the measured number lies above the stated range.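

Methyl in place of hydrogen on the oxygen does not carry over between the two cores in this assay. On the core that bears the extra methoxy, the same change gives a 3.6-fold higher number from compound 3 to compound 4 (0.55 log units; beyond the scatter), which runs against the direction seen on the core of compound 1, and the two steps differ clearly: the same change on two cores in this assay, a 3.2-fold lower number (0.51 log units; beyond the scatter) from compound 1 to compound 2 and a 3.6-fold higher number (0.55 log units; beyond the scatter) from compound 3 to compound 4, 11-fold (1.06 log units) apart, beyond the scatter of two such steps

The extra methoxy depends on its partner in the same way, with a 5.6-fold higher number from compound 2 to compound 4 (0.75 log units; beyond the scatter) where the methyl is already present, against a lower number where the free hydroxy group remains: the same change on two cores in this assay, a 2.0-fold lower number (0.31 log units; beyond the scatter) from compound 1 to compound 3 and a 5.6-fold higher number (0.75 log units; beyond the scatter) from compound 2 to compound 4, 11-fold (1.06 log units) apart, beyond the scatter of two such steps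

This shows that, across these four compounds, the two changes cannot simply be added together, but it does not show why they interact or whether the same holds for any other compound in the series.

The compounds shown leave open whether this reversal is particular to methoxy, or would also appear with an ethyl group on the same oxygen or with an amine in place of the hydroxy group. Going by these compounds, it also remains open whether the same reversal would appear in cell lines other than the one used here.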